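Replacing the oxane chain with a carbamoylcyclohexyl group

This account rests on a few compounds, and the source may have more. Where it says the series, first, only, none or still open, it means among the compounds named here.

Measured compounds:
Compound 1, `N#Cc1cnc(NCc2cnccc2C(F)(F)F)cc1NC[C@H]1CC[C@@H](O)CC1`: 500 nM
Compound 2, `N#Cc1cnc(NCc2cnccc2C(F)(F)F)cc1NC1CCOCC1`: 9800 nM
Compound 3, `N#Cc1cnc(NCc2cnccc2C(F)(F)F)cc1NCCC1CCOCC1`: > 10000 nM

All three share one core and differ only in the group on a nitrogen on an aromatic ring. In an assay on isolated protein for inhibition of protein kinase C delta type (Homo sapiens), read by TR-FRET, with a stated time of 2 h (a lower number here means a stronger inhibitor, a higher number a weaker inhibitor), compound 1 gives the lowest number shown. The value of compound 3 is a limit of the assay, not a number, as the limit of > 10000 nM in this assay, at which 1 of the 3 values shown sits, notes. Compound 2 gives a number close to that limit, and the pair shows an at least 1.0-fold higher number from compound 2 to compound 3 (0.00 log units; that floor lies within the scatter).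

Compound 4, `N#Cc1cnc(NCc2cnccc2C(F)(F)F)cc1N[C@H]1CC[C@@H](C(N)=O)CC1`, has not yet been measured. Its change from compound 3 is 4-carbamoylcyclohexyl in place of 2-(oxan-4-yl)ethyl on a nitrogen on an aromatic ring. For the measured compounds named here, two measured steps bear on this: a 20-fold higher number from compound 1 to compound 2 (1.29 log units; beyond the scatter) and an at least 20-fold higher number from compound 1 to compound 3 (1.30 log units; beyond the scatter). Both show that swapping the hydroxycyclohexyl-bearing side group of compound 1 for an oxane-based one loses a great deal. Compound 4 returns to a cyclohexyl ring with a polar group, though attached to the nitrogen directly, as in compound 2. A large improvement is therefore expected, an at least 6.6-fold lower number from compound 3 to compound 4 (0.82 log units; beyond the scatter), though not the full recovery to compound 1. For compound 4 the expected value is 1500 nM, in the range 300 nM to 8000 nM.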

Compound 4, half-maximal inhibitory concentration: 400 nM
For compound 4 the middle estimate is 3.8-fold (0.57 log units) above the measured one; measured number inside the range.
By their numbers in this assay, from the lowest: compounds 4 and 1 (each within the scatter of the next); then compound 2. At a limit, above all of these: compound 3.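

With the ring attached directly to the nitrogen in both compounds, the change from oxan-4-yl to 4-carbamoylcyclohexyl gives a 25-fold lower number from compound 2 to compound 4 (1.39 log units; beyond the scatter), so direct attachment alone does not rule out a low number at this position, and the change from 2-(oxan-4-yl)ethyl gives an at least 25-fold lower number from compound 3 to compound 4 (1.39 log units; beyond the scatter). The position accepts two quite different cyclohexyl-containing groups with no difference beyond the scatter, as a 1.3-fold lower number from compound 1 to compound 4 (0.10 log units; within the scatter) shows. The value of compound 3 is a limit of the assay, not a number: the limit of > 10000 nM in this assay, at which 1 of the 4 values shown sits.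

As far as these compounds go, what remains open is whether the carbamoyl group or the carbon-only ring accounts for the result, which a plain cyclohexyl or a 4-carboxycyclohexyl group on the same nitrogen would help to separate. The compounds shown also do not tell how the other stereoisomer of the 4-carbamoylcyclohexyl group, or a (4-carbamoylcyclohexyl)methyl group, would compare.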